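Swapping a dichlorophenyl for a benzoyl on the sulfur chain

A few compounds are considered here, and "the series" means these few. Any claim that something is new, unique, unknown or untested is made for them only; others in the source may bear on it.

Measured compounds:
Compound 1 `Cc1cc(Nc2cc(-c3ccccc3)[nH]n2)n2nc(SCc3c(Cl)cccc3Cl)nc2n1`: 5180 nM
Compound 2 `Cc1cc(Nc2ccn(Cc3ccc(C(F)(F)F)cc3)n2)n2nc(SCc3ccc(Br)cc3)nc2n1`: 5580 nM

Of the compounds shown here, two have been tested in a functional assay on PC-9 cells (Homo sapiens) for inhibition, read by MTT assay, with a stated time of 72 h; on this read-out lower numbers stand for stronger inhibition and higher numbers for weaker inhibition. Compound 1 gives 5180 nM, and compound 2 gives 5580 nM. Compound 1 has the smaller of the two numbers, but the two values lie within the usual scatter of repeated measurements, so neither compound can be called more or less potent than the other.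

Compound 3 `Cc1cc(Nc2cc(-c3ccccc3)[nH]n2)n2nc(SCC(=O)c3ccccc3)nc2n1` has not yet been measured. It differs from compound 1 in one place: benzoyl in place of 2,6-dichlorophenyl on a saturated chain carbon bound to a sulfur. The shared core and the rest of the molecule are unchanged.

For the measured compounds named here, no pair of measured compounds shows what such a change does. Both measured values sit close together, so there is no sign of large swings in this series. The step from compound 1 to compound 3 is therefore expected to be small, a 1.2-fold higher number from compound 1 to compound 3 (0.06 log units; within the scatter), with no clear direction beyond the scatter. Compound 3 is estimated at 6000 nM, in a range from 2000 nM to 20000 nM.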

Compound 3, half-maximal inhibitory concentration: 4450 nM
Estimate against measurement, compound 3: 1.3-fold (0.13 log units) above; measured number inside the range.
By their numbers in this assay, from the lowest: compounds 3, 1 and 2 (each within the scatter of the next).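

In this assay, for the compounds shown here, putting benzoyl in place of 2,6-dichlorophenyl on a saturated chain carbon bound to a sulfur gives a 1.2-fold lower number from compound 1 to compound 3 (0.07 log units; within the scatter), the first direct reading of a change at this position. Compound 1 and compound 3 therefore read alike, which shows that this position can carry benzoyl, with its carbonyl and without chlorine, and no shift beyond the usual scatter appears in this read-out. Nothing measured here says why these two different groups read alike.

Going by these compounds, it remains open whether any group at this position can move the number beyond the scatter, and whether an amine, a carboxylic acid or a longer chain in place of benzoyl would do so. On these data alone, it is equally open whether the same swap would read alike if the rest of the molecule were different.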